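Shifting a trifluoromethyl around a ring in a cell assay

The source may report more compounds than this note shows. Statements on the series, on what has been measured and on what is new or still open speak of the compounds shown alone.

Measured compounds:
compound 1, `CN(C(=O)NC(=O)c1ccccc1F)c1nc(C(F)(F)F)c(C(=O)N/N=C/c2ccccc2C(F)(F)F)s1`, 6.32 ug/mL
compound 2, `CN(C(=O)NC(=O)c1ccccc1F)c1nc(C(F)(F)F)c(C(=O)N/N=C/c2cccc(C(F)(F)F)c2)s1`, 19.5 ug/mL

Both were tested in a functional assay on A549 cells (Homo sapiens) for inhibition, read by MTT assay, with a stated time of 72 h; a higher number here means a weaker inhibitor, a lower number a stronger inhibitor. Going by the values given here, compound 1 gives 6.32 ug/mL, and compound 2 gives 19.5 ug/mL, the highest number of the two; the only step between them is a 3.1-fold higher number from compound 1 to compound 2 (0.49 log units; beyond the scatter).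

Compound 3, `CN(C(=O)NC(=O)c1ccccc1F)c1nc(C(F)(F)F)c(C(=O)N/N=C/c2ccc(C(F)(F)F)cc2)s1`, has not yet been measured. It differs from compound 2 in one place: 4-(trifluoromethyl)phenyl in place of 3-(trifluoromethyl)phenyl on a carbon with a double bond to nitrogen.

Among the compounds with values here, only one measured step bears on this, a 3.1-fold higher number from compound 1 to compound 2 (0.49 log units; beyond the scatter), and it concerns a different pair of positions for the same group on the same carbon. Within the data shown here, no step in the data compares the 3- and 4- positions directly, so the direction of a 1.1-fold higher number from compound 2 to compound 3 (0.05 log units; within the scatter) is uncertain and is expected to be modest, possibly within the scatter. Compound 3 is therefore estimated to give about 22 ug/mL, in a range from 8 ug/mL to 60 ug/mL.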

Compound 3, half-maximal inhibitory concentration: 5.68 ug/mL
Compound 3: middle estimate off by 3.9-fold (0.59 log units), on the high side; the measured number lies below the stated range.
By their numbers in this assay, from the lowest: compounds 3 and 1 (each within the scatter of the next); then compound 2.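

The change to 4-(trifluoromethyl)phenyl brings a 3.4-fold lower number from compound 2 to compound 3 (0.54 log units; beyond the scatter) and so shows that the number does not simply climb as the trifluoromethyl changes position on the ring: compound 2 is the one that stands apart. Going from 2-(trifluoromethyl)phenyl to 4-(trifluoromethyl)phenyl gives a 1.1-fold lower number from compound 1 to compound 3 (0.05 log units; within the scatter) and so leaves these two placements indistinguishable here, while the 3-(trifluoromethyl)phenyl compound alone lies beyond the scatter from both others. Nothing available here accounts for this difference.

From the compounds shown here alone, whether the same pattern across the ring would appear with another group in place of trifluoromethyl, such as a nitrile or a carboxylic acid, remains open. So does whether it would hold if the ring on the carbon with a double bond to nitrogen carried an amine instead.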